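Swapping one group on compound 3

The compounds below may be only part of what the source reports. "The series", "measured", "known", "first", "only" and "open" are said of these compounds alone.

Four related compounds are in view here. In an ADME assay for pharmacokinetics (on this read-out lower numbers stand for a shorter-lived compound and higher numbers for a longer-lived compound), compound 1 `C[C@H](NC(=O)OC(C)(C)C)C(=O)N[C@@H](C)C(=O)Nc1ccc2c(Cl)c(OCCSC(=N)N)oc(=O)c2c1` gives 0.667 h, compound 2 `N=C(N)SCCOc1oc(=O)c2cc(NC(=O)NC(c3ccccc3)c3ccccc3)ccc2c1Cl` gives 2.8 h and compound 3 `N=C(N)SCCCOc1oc(=O)c2cc(NC(=O)NCc3ccccc3)ccc2c1Cl` gives 2.47 h. Compound 3 therefore lies within the usual scatter of compound 2, so those two numbers cannot be told apart, while it stands clearly above compound 1.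

Compound 4 `N=C(N)SCCCOc1oc(=O)c2cc(NC(=O)CCc3ccccc3)ccc2c1Cl` has not yet been measured. It differs from compound 3 in one place: phenethyl in place of benzylamino on a carbonyl carbon, which means phenethyl in place of benzylamino on a carbonyl carbon. Going by the values given here, no measured pair shows this exchange, so the data give no direct guide to its size. The best anchor is compound 3 at 2.47 h, and no step beyond the scatter is expected in this assay. The expected change is a 1.1-fold lower number from compound 3 to compound 4 (0.05 log units; within the scatter), which stays within the scatter. The estimated value for compound 4 is 2.2 h, with an expected range from 1.1 h to 4.4 h.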

Compound 4, half-life: 1.1 h
Beside the measured number, compound 4's estimate is 2.0-fold (0.30 log units) above it; measured number inside the range.
By their numbers in this assay, from the lowest: compounds 1 and 4 (each within the scatter of the next); then compounds 3 and 2 (each within the scatter of the next).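

Going by these compounds alone, this is the first step in the set that changes only one place: in this assay, putting phenethyl in place of benzylamino on a carbonyl carbon gives a 2.2-fold lower number from compound 3 to compound 4 (0.35 log units; beyond the scatter). The read-out therefore responds to this position even though the two groups have the same number of heavy atoms and the same aromatic ring of carbon only; what differs is that a nitrogen carrying a hydrogen-bond donor gives way to a carbon with none. No measurement shown here accounts for the shorter half-life.

On these data alone, this exchange is seen on one pair only, so whether it would act alike on a compound with a different chain on the shared core remains open. Also open, as far as these compounds go, is how a benzyloxy group or a longer phenylpropyl chain on the same carbonyl carbon would compare.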